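Replacing 2,6-dichlorophenyl with benzoyl: an expected loss

A few compounds are considered here, and "the series" means these few. Any claim that something is new, unique, unknown or untested is made for them only; others in the source may bear on it.

compound 1 (`Cc1cc(Nc2cc(-c3ccccc3)[nH]n2)n2nc(SCc3c(Cl)cccc3Cl)nc2n1`): 5180 nM
compound 2 (`Cc1cc(Nc2ccn(Cc3ccccc3)n2)n2nc(SCc3ccc(Br)cc3)nc2n1`): > 50000 nM (a limit of the assay, not a number)
compound 3 (`CCCCCc1c(C)nc2nc(SCc3ccc(Cl)cc3)nn2c1Nc1cc(-c2ccccc2)[nH]n1`): > 50000 nM (a limit of the assay, not a number)

Among the measured compounds shown here, all three compounds were tested in a functional assay on PC-9 cells (Homo sapiens) for inhibition, read by MTT assay, with a stated time of 72 h (a higher number here means a weaker inhibitor, a lower number a stronger inhibitor), and compound 1 gives 5180 nM as the only true number among them. For the measured compounds named here, the other two readings are limits, so the set is dominated by the limit of > 50000 nM in this assay, at which 2 of the 3 values shown sit, and offers no measured step to compare.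

Compound 4 (`Cc1cc(Nc2cc(-c3ccccc3)[nH]n2)n2nc(SCC(=O)c3ccccc3)nc2n1`) keeps the core of compound 1 and changes one group (benzoyl in place of 2,6-dichlorophenyl on a saturated chain carbon bound to a sulfur) with benzoyl in place of 2,6-dichlorophenyl on a saturated chain carbon bound to a sulfur. Going by the values given here, no measured pair isolates this change, so any forecast rests on thin ground. A moderately weaker compound 4 is expected, a step somewhat beyond the scatter, because the limit of > 50000 nM in this assay, at which 2 of the 3 values shown sit, shows that compounds in this set often give no number, while compound 1 with 5180 nM is the single measured reference. The estimated move is a 2.3-fold higher number from compound 1 to compound 4 (0.36 log units; beyond the scatter) and it carries wide uncertainty. In this assay the estimated value for compound 4 is 12000 nM within an expected range of 3500 nM to 40000 nM as a working guess.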

Compound 4, half-maximal inhibitory concentration: 4450 nM
Beside the measured number, compound 4's estimate is 2.7-fold (0.43 log units) above it; low and high end bracket the measured number.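

In this assay, putting benzoyl in place of 2,6-dichlorophenyl on a saturated chain carbon bound to a sulfur gives a 1.2-fold lower number from compound 1 to compound 4 (0.07 log units; within the scatter), so the two compounds cannot be told apart. Among the compounds shown here, this is the only measured step at this place, and it shows that both chlorine atoms can leave and a carbonyl can enter, at an equal count of heavy atoms, without a visible change in the reading. Compound 4 also gives a true number rather than a limit, as compound 1 does, which cannot be taken for granted in this set: the limit of > 50000 nM in this assay, at which 2 of the 4 values shown sit.

For the compounds shown here, the single step changes two things at once, so it remains open whether removing the chlorine atoms and adding the carbonyl each leave the reading untouched or whether their separate effects cancel. Going by these compounds, it also remains open how far this tolerance extends, for instance whether an amine or a carboxylic acid in place of the benzoyl on the same saturated chain carbon would keep a number of this size.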